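Diarylaminopyrimidine series: change of the anilino aryl group

This account rests on a few compounds, and the source may have more. Where it says the series, first, only, none or still open, it means among the compounds named here.

Measured so far in a functional assay on MDA-MB-231 cells (Homo sapiens) for cytotoxicity, read by MTT assay, with a stated time of 72 h; on this read-out lower numbers stand for stronger inhibition and higher numbers for weaker inhibition:
compound 1 `Fc1cc(Nc2cc(Nc3cccc(Cl)c3)ncn2)ccc1Oc1ccncc1-c1cccnc1` gives 90 nM
compound 2 `Fc1ccc(Nc2cc(Nc3ccc(Oc4ccncc4-c4cccnc4)c(F)c3)ncn2)cc1` gives 14100 nM

Compound 2 stands highest of the two numbers; compound 1 is the nearest and sits far lower, the step being a 160-fold higher number from compound 1 to compound 2 (2.19 log units; beyond the scatter). Compound 3 `COc1cc(Nc2cc(Nc3ccc(Oc4ccncc4-c4cccnc4)c(F)c3)ncn2)cc(OC)c1` carries 3,5-dimethoxyphenyl in place of 4-fluorophenyl on a nitrogen on an aromatic ring. Within the data shown here, no measured step covers this exact change; the only step shows that the aryl group on this nitrogen moves the number strongly. Given that sensitivity, compound 3 is expected to come in lower than compound 2, with the step estimated as a 9.4-fold lower number from compound 2 to compound 3 (0.97 log units; beyond the scatter). The estimate for compound 3 is 1500 nM, within a range of 200 nM to 10000 nM.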

Compound 3, half-maximal inhibitory concentration: 4240 nM
Estimate against measurement, compound 3: 2.8-fold (0.45 log units) below, within the range that was stated.
By their numbers in this assay, from the lowest: compound 1; then compound 3; then compound 2.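

In this assay, 3,5-dimethoxyphenyl on this nitrogen improves on 4-fluorophenyl (a 3.3-fold lower number from compound 2 to compound 3 (0.52 log units; beyond the scatter)) but falls well short of 3-chlorophenyl (a 47-fold higher number from compound 1 to compound 3 (1.67 log units; beyond the scatter)). Compound 1 therefore remains the lowest of the three, and neither replacement comes close to it. No evidence is available to explain this order.

On these data alone, it remains open whether an amine or a carboxylic acid on this aryl ring would bring the number closer to that of compound 1. As far as these compounds go, the effect of a bromine atom in place of the chlorine also remains open.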